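A few compounds are considered here, and "the series" means these few. Any claim that something is new, unique, unknown or untested is made for them only; others in the source may bear on it.

Compound 1 `C=C(c1ccc(Cl)c(Cl)c1Cl)C1COC2(CCCC2)OO1` and compound 2 `C=C(c1ccc(Cl)cc1Cl)C1COC2(CCCC2)OO1` share one core and differ by hydrogen in place of chloro on an aromatic carbon. In a functional assay on L02 cells (Homo sapiens) for inhibition, read by MTT assay, with a stated time of 72 h (on this read-out higher numbers stand for weaker inhibition and lower numbers for stronger inhibition), compound 1 gives 1190 nM, and compound 2 gives 2550 nM; the step between them is a 2.1-fold higher number from compound 1 to compound 2 (0.33 log units; beyond the scatter). Compound 3 `C=C(c1ccc(Cl)c(Cl)c1Cl)C1COC(C)(C)OO1` carries the same aromatic ring as compound 1 on a different core, and the difference between the two cores is not broken down here. In this assay compound 3 gives 18100 nM, the highest of the three numbers. Compound 4 `C=C(c1ccc(Cl)cc1Cl)C1COC(C)(C)OO1` stands to compound 3 as compound 2 stands to compound 1: hydrogen in place of chloro on an aromatic carbon, the same change at the same place. Going by the values given here, the expected step is a 2.1-fold higher number from compound 3 to compound 4 (0.32 log units; beyond the scatter), resting on the single measured example of this change, a 2.1-fold higher number from compound 1 to compound 2 (0.33 log units; beyond the scatter). Compound 4 is therefore estimated at 38000 nM, most likely between 15000 nM and 100000 nM.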

Compound 4, half-maximal inhibitory concentration: 37700 nM
Compound 4: middle estimate off by 1.0-fold (0.00 log units), on the high side; the measured number falls inside the stated range.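

Replacing the chloro group with hydrogen gives a 2.1-fold higher number from compound 3 to compound 4 (0.32 log units; beyond the scatter) in this assay, so inhibition is weaker on this core too. Set beside the earlier step, the two steps agree: the same change on two cores in this assay, a 2.1-fold higher number (0.33 log units; beyond the scatter) from compound 1 to compound 2 and a 2.1-fold higher number (0.32 log units; beyond the scatter) from compound 3 to compound 4, 1.0-fold (0.01 log units) apart, within the scatter of two such steps. In these two pairs the change therefore carries over from one core to the other with its size kept, but two pairs at one place on the ring, in a single assay, cannot show that it would hold on other cores or explain why the step has this size.

The compounds shown leave open what a group such as fluoro, methoxy or an amine would do at that place on the ring. As far as these compounds go, it also remains open whether the step would persist on a core carrying a longer chain.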